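A few compounds are considered here, and "the series" means these few. Any claim that something is new, unique, unknown or untested is made for them only; others in the source may bear on it.

In a functional assay on MCF7 cells (Homo sapiens) for cytotoxicity, read by MTT assay, with a stated time of 72 h (a lower number here means a stronger inhibitor, a higher number a weaker inhibitor), compound 1 `O=C1C(=Cc2ccc(Br)cc2)C(=O)N(c2ccc(Cl)cc2)N1c1ccc(Cl)cc1` gives 30400 nM and compound 2 `O=C1C(=Cc2ccco2)C(=O)N(c2ccc(Cl)cc2)N1c1ccc(Cl)cc1` gives 20300 nM. For the measured compounds named here, compound 2 therefore stands within the scatter of compound 1, the only other measured member of the series. Compound 3 `O=C1C(=Cc2ccccc2)C(=O)N(c2ccc(Cl)cc2)N1c1ccc(Cl)cc1` has the same core and carries phenyl in place of furan-2-yl on a double-bonded chain carbon bound to a double-bonded ring carbon. Going by the values given here, one measured step bears on this change, as it alters the same place: a 1.5-fold lower number from compound 1 to compound 2 (0.18 log units; within the scatter), which lies within the scatter. Among the compounds with values here, with only this small step as a guide, no step beyond the scatter is expected in this assay, and the direction remains uncertain. The expected change is a 1.2-fold higher number from compound 2 to compound 3 (0.09 log units; within the scatter), which would also lie within the scatter. For compound 3 the estimated value is 25000 nM, with an expected range from 11000 nM to 55000 nM.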

Compound 3, half-maximal inhibitory concentration: 20200 nM
The estimate for compound 3 lay 1.2-fold (0.09 log units) above the measured number; the range from low to high includes it.
By their numbers in this assay, from the lowest: compounds 3, 2 and 1 (each within the scatter of the next).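

In this assay, phenyl in place of furan-2-yl on a double-bonded chain carbon bound to a double-bonded ring carbon gives a 1.0-fold lower number from compound 2 to compound 3 (0.00 log units; within the scatter), so this assay does not separate the five-membered aromatic ring with its hetero atom from the six-membered aromatic ring of carbon only. Hydrogen in place of bromo on an aromatic carbon gives a 1.5-fold lower number from compound 1 to compound 3 (0.18 log units; within the scatter), so the bromo of compound 1 also leaves no step beyond the scatter, and all three aromatic groups at this position give numbers within the scatter of one another. No independent data bear on why these groups read alike.

From the compounds shown here alone, it remains open whether a group of another kind at this position, such as an amine, a carboxylic acid or a longer chain, would give a step beyond the scatter. The compounds shown also leave open how far the number depends on the rest of the shared core, which stays the same in all three.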